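The source may report more compounds than this note shows. Statements on the series, on what has been measured and on what is new or still open speak of the compounds shown alone.

Measured compounds:
- compound 1, `c1ccc(-c2cnco2)c(NCC2=NCCN2)c1`: 17.4 nM
- compound 2, `Cc1cc(-c2ccccc2NCC2=NCCN2)on1`: 38.9 nM
- compound 3, `Cc1noc(-c2ccccc2NCC2=NCCN2)n1`: 661 nM

All three share the same core and differ only in the five-membered aromatic ring attached to it. In a functional assay for activation of Alpha-1A adrenergic receptor (Homo sapiens), read by calcium flux (a higher number here means that more compound is needed for the effect, a lower number that less compound is needed), compound 3 gives the highest number of the three, well beyond the scatter from both others: a 17-fold higher number from compound 2 to compound 3 (1.23 log units; beyond the scatter) and a 38-fold higher number from compound 1 to compound 3 (1.58 log units; beyond the scatter).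

Compound 4, `Cc1ccc(-c2ccccc2NCC2=NCCN2)o1`, is not yet measured. Relative to compound 3 the change is 5-methylfuran-2-yl in place of 3-methyl-1,2,4-oxadiazol-5-yl on an aromatic carbon. The ring that enters carries a single hetero atom, as does the ring of compound 1 and that of compound 2, whereas the ring that leaves carries three.

Among the compounds with values here, the steps that bear on this are the two leading into compound 3, both large and both in the direction of a higher number. The reverse is therefore expected here: a large step toward a lower number, a 19-fold lower number from compound 3 to compound 4 (1.28 log units; beyond the scatter), bringing compound 4 back near the range of compound 1 and compound 2. Within the data shown here, no measured step shows the exact ring of compound 4, so the range is kept wide.

Compound 4 is estimated at 35 nM, with a range from 10 nM to 120 nM in this assay.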

Compound 4, half-maximal effective concentration: 2.69 nM
Compound 4: middle estimate off by 13-fold (1.11 log units), on the high side, and the stated range ends above it.
By their numbers in this assay, from the lowest: compound 4; then compound 1; then compound 2; then compound 3.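

In this assay, within the data shown here, this ortho position spans a far wider range than the earlier compounds showed, with a 250-fold lower number from compound 3 to compound 4 (2.39 log units; beyond the scatter) for a swap that keeps 6 heavy atoms and one five-membered aromatic ring but goes from 3 hetero atoms to 1. Among these compounds, the number also falls past both rings that had set the low end, with a 14-fold lower number from compound 2 to compound 4 (1.16 log units; beyond the scatter) and a 6.5-fold lower number from compound 1 to compound 4 (0.81 log units; beyond the scatter), so compound 4 now marks the low end of the four and the earlier compounds did not mark the floor at this position. No measurement at hand explains the size of these steps.

Still open, from the compounds shown here alone, is how much of the low number belongs to the methyl group and how much to the furan ring itself. An unsubstituted furan-2-yl, an ethyl in place of the methyl, or a thiophene ring would separate the two.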